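Hydroxymethyl in place of methoxymethyl on the diarylmethane chain

This account rests on a few compounds, and the source may have more. Where it says the series, first, only, none or still open, it means among the compounds named here.

Compound 1 `COC[C@@H](C(C)C)C(c1ccc(O)c(OC)c1)c1ccc(O)c(OC)c1` gives 69000 nM in a functional assay on HeLa cells (Homo sapiens) for cytotoxicity, read by WST assay, with a stated time of 48 h (on this read-out higher numbers stand for weaker inhibition and lower numbers for stronger inhibition), the higher of the two numbers in hand. Compound 2 `COc1cc(C(c2ccc(O)c(OC)c2)[C@H](C)[C@@H](C)CF)ccc1O` gives 34000 nM in this assay. Compound 3 `COc1cc(C(c2ccc(O)c(OC)c2)[C@@H](C)[C@@H](C)CO)ccc1O` reaches only a limit in this assay, > 100000 nM. Compound 4 `COc1cc(C(c2ccc(O)c(OC)c2)[C@H](C)[C@@H](C)CO)ccc1O` awaits measurement; against compound 1 it carries 2-(hydroxymethyl)-1-methylpropyl in place of 1-(methoxymethyl)-2-methylpropyl on a saturated chain carbon bound to two aromatic carbons. The entry of the hydroxymethyl group has been seen twice: an at least 1.4-fold higher number from compound 1 to compound 3 (0.16 log units; that floor lies within the scatter), and an at least 2.9-fold higher number from compound 2 to compound 3 (0.46 log units; beyond the scatter); by contrast a 2.0-fold lower number from compound 1 to compound 2 (0.31 log units; beyond the scatter). Both hydroxymethyl steps point toward weaker inhibition, the second beyond the scatter, so an upward step is expected for compound 4, with a real chance that only a limit is returned because the limit of > 100000 nM in this assay, at which 1 of the 3 values shown sits, is where compound 3 sits. Compound 4 is therefore estimated at 110000 nM, between 50000 nM and 250000 nM, which is a 1.6-fold higher number from compound 1 to compound 4 (0.20 log units; within the scatter).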

Compound 4, half-maximal inhibitory concentration: > 100000 nM
Compound 4: only a limit was reported; the forecaster's own chance of this, stated with the estimate: 55%; the middle value does not contradict the limit.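

In this assay, hydroxy in place of fluoro gives an at least 2.9-fold higher number from compound 2 to compound 4 (0.46 log units; beyond the scatter), the same direction as the step to compound 3, so both drawn configurations of the hydroxymethyl chain lie on the weaker side of the fluoromethyl compound. Against the methoxymethyl chain, the change gives an at least 1.4-fold higher number from compound 1 to compound 4 (0.16 log units; that floor lies within the scatter), so no real step from compound 1 is established. Compound 3 and compound 4 both end at a limit, so the step between them cannot be read and the stereocentre's contribution stays unresolved: the fact that compounds 3 and 4 differ only in the configuration as drawn

From the compounds shown here alone, whether an amine or a carboxylic acid in place of the hydroxy would give a readable number remains open.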